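The source may report more compounds than this note shows. Statements on the series, on what has been measured and on what is new or still open speak of the compounds shown alone.

Measured compounds:
compound 1, `Fc1cccc(-c2nc(Nc3ccccc3)c3ccccc3n2)c1`, > 50000 nM
compound 2, `Fc1cccc(Nc2nc(-c3cccc(F)c3)nc3ccc(F)cc23)c1`, 48700 nM

In a functional assay on MCF7 cells (Homo sapiens) for cytotoxicity, read by MTT assay, with a stated time of 48 h (a lower number here means a stronger inhibitor, a higher number a weaker inhibitor), compound 1 gives only a limit, > 50000 nM. In this assay, among the measured compounds shown here, compound 2 gives 48700 nM, the only number in the set, the other entry sitting at the limit of > 50000 nM in this assay, at which 1 of the 2 values shown sits. Compound 3, `Fc1cccc(-c2nc(Nc3cccc(Br)c3)c3cc(F)ccc3n2)c1`, is not yet measured. It differs from compound 2 by bromo in place of fluoro on an aromatic carbon. For the measured compounds named here, no measured step covers this change; the expected step is small, none beyond the scatter, with no clear direction. Compound 3 is expected to give 35000 nM in this assay, between 15000 nM and 60000 nM. The step expected is a 1.4-fold lower number from compound 2 to compound 3 (0.14 log units; within the scatter).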

Compound 3, half-maximal inhibitory concentration: > 50000 nM
Compound 3 ended at the assay's limit; the forecaster's own chance of this, stated with the estimate: 35%; at least 1.4-fold (0.15 log units) between middle value and limit.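

Swapping (3-fluorophenyl)amino for (3-bromophenyl)amino gives an at least 1.0-fold higher number from compound 2 to compound 3 (0.01 log units; that floor lies within the scatter) in this assay, so only a floor on this step can be read, and its true size stays unknown. Compound 3 gives > 50000 nM, which is a limit of the assay. This change at this position therefore brings no measurable move toward a lower number, and the set gains a second compound at that limit: the limit of > 50000 nM in this assay, at which 2 of the 3 values shown sit.

On these data alone, whether an amine or a carboxylic acid at this position would give a number clear of the limit remains open. So does how far compound 3 lies beyond it.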